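The source may report more compounds than this note shows. Statements on the series, on what has been measured and on what is new or still open speak of the compounds shown alone.

Measured compounds:
- Compound 1 `COc1cc(-c2nn(-c3cccc(NC(=O)c4ccc(Cl)c(C(F)(F)F)c4)c3)cc2-c2ccncc2)ccc1Cl` — in a functional assay on U-251 cells (Homo sapiens) for inhibition, read by sulforhodamine B assay, with a stated time of 48 h (on this read-out lower numbers stand for higher toxicity in this test and higher numbers for lower toxicity in this test), compound 1 gives > 32500 nM, which is a limit of the assay.
- Compound 2 `COc1cc(-c2nn(-c3cccc(NC(=O)Nc4cccc(C(F)(F)F)c4)c3)cc2-c2ccncc2)ccc1Cl` — in this assay compound 2 gives 2920 nM.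
- Compound 3 `O=C(Nc1cccc(-n2cc(-c3ccncc3)c(-c3ccc(Cl)c(O)c3)n2)c1)Nc1cccc(C(F)(F)F)c1` — in this assay compound 3 gives > 32500 nM, which is a limit of the assay.

Compound 2 is the only one of the three with a numerical value; the other two sit at the limit of > 32500 nM in this assay, at which 2 of the 3 values shown sit. Compound 4 `COc1cc(-c2nn(-c3cccc(NC(=O)Nc4ccc(Cl)c(Cl)c4)c3)cc2-c2ccncc2)ccc1Cl` differs from compound 2 by 3,4-dichlorophenyl in place of 3-(trifluoromethyl)phenyl on an amide-type nitrogen. Among the compounds with values here, no measured step changes this same group. The nearest step, an at least 11-fold lower number from compound 1 to compound 2 (1.04 log units; beyond the scatter), altered the group on the carbonyl carbon and was large, while an at least 11-fold higher number from compound 2 to compound 3 (1.04 log units; beyond the scatter) concerns a remote methyl. Neither tests a halogenated phenyl against a trifluoromethyl phenyl on the urea nitrogen, so no step beyond the scatter is expected in this assay. Compound 4 is therefore estimated at 3000 nM, within 900 nM to 10000 nM, an expected step of a 1.0-fold higher number from compound 2 to compound 4 (0.01 log units; within the scatter).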

Compound 4, concentration lethal to 50% of the cells: > 50000 nM
Compound 4 gave a limit, no number (the forecaster's own chance of this, stated with the estimate: 15%); middle value at least 16-fold (1.22 log units) away from the limit.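

With the rest of the molecule unchanged, replacing 3-(trifluoromethyl)phenyl with 3,4-dichlorophenyl on the amide-type nitrogen gives an at least 17-fold higher number from compound 2 to compound 4 (1.23 log units; beyond the scatter) in this assay, so the aryl group at this place alone can separate a measurable value from none. Compound 4 sits at a limit, not a number: the limit of > 50000 nM in this assay, at which 1 of the 4 values shown sits. The step from compound 1 to compound 4 cannot be read.

Going by these compounds, it remains open whether the added chlorine or the lost trifluoromethyl counts more. A nitrile or an amine on this phenyl ring is also untested here.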